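The source may report more compounds than this note shows. Statements on the series, on what has been measured and on what is new or still open speak of the compounds shown alone.

Measured so far in a functional assay on MCF7 cells (Homo sapiens) for antiproliferative activity, read by MTT assay, with a stated time of 72 h; on this read-out lower numbers stand for stronger inhibition and higher numbers for weaker inhibition:
compound 1, `CC(=O)OCC(CCn1cc(C#CCCCCl)c(=O)n(C(=O)c2ccccc2)c1=O)COC(C)=O`, gives 21000 nM
compound 2, `CC(=O)OCC(CCn1cc(C#CC(C)(C)C)c(=O)n(C(=O)c2ccccc2)c1=O)COC(C)=O`, gives 67100 nM
compound 3, `O=c1[nH]c(=O)n(CCC(CO)CO)cc1C#CCCCCl`, gives 35200 nM

Compound 4, `CC(C)(C)C#Cc1cn(CCC(CO)CO)c(=O)[nH]c1=O`, has not yet been measured. It differs from compound 3 by tert-butyl in place of 3-chloropropyl on a triple-bonded carbon. The same change, (tert-butyl in place of 3-chloropropyl on a triple-bonded carbon), has been made once already among these compounds: it gave a 3.2-fold higher number from compound 1 to compound 2 (0.50 log units; beyond the scatter), that is, a weakening of the antiproliferative effect. The difference between the core of compound 1 and the core of compound 3 is not broken down here, so the two pairs share only the change itself, which sits at the same place in both. The step from compound 3 to compound 4 is expected to resemble the earlier one, a 2.8-fold higher number from compound 3 to compound 4 (0.45 log units; beyond the scatter), because compound 2 showed a 3.2-fold higher number from compound 1 to compound 2 (0.50 log units; beyond the scatter). Compound 4 is therefore estimated at 100000 nM, within a range from 40000 nM to 250000 nM.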

Compound 4, half-maximal inhibitory concentration: 95900 nM
Compound 4: the middle estimate sits 1.0-fold (0.02 log units) above what was measured; measured number inside the range.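

In this assay, putting tert-butyl in place of 3-chloropropyl on the triple-bonded carbon again weakens the effect on the core of compound 3, giving a 2.7-fold higher number from compound 3 to compound 4 (0.44 log units; beyond the scatter). Set beside the earlier step, the change carries over from one core to the other at much the same size: the same change on two cores in this assay, a 3.2-fold higher number (0.50 log units; beyond the scatter) from compound 1 to compound 2 and a 2.7-fold higher number (0.44 log units; beyond the scatter) from compound 3 to compound 4, 1.2-fold (0.07 log units) apart, within the scatter of two such steps. Within the data shown here, these are only two pairs, so this shows that the step held on these two cores, but not that it would hold on others, and it does not explain why the number rises.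

As far as these compounds go, it remains open whether other groups in this place, such as an amine-bearing chain or a longer chain, would follow the same trend. Also open, from the compounds shown here alone, is how much each part of the difference between the core of compound 1 and the core of compound 3 contributes on its own.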